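Methoxy in place of methyl near the clearance limit

A few compounds are considered here, and "the series" means these few. Any claim that something is new, unique, unknown or untested is made for them only; others in the source may bear on it.

In an ADME assay on microsomes from liver (Homo sapiens) for metabolic stability (a lower number here means slower removal, a higher number faster removal of the compound), compound 3 `Cc1cnc(-c2cc(Oc3ccc(S(C)(=O)=O)cc3)cc(OC(C)C)c2)[nH]c1=O` gives < 8 mL/min/kg, which is a limit and not a number. Compound 1 `CC(C)Oc1cc(Oc2ccc(S(C)(=O)=O)cc2)cc(-c2cccc(=O)[nH]2)c1` gives < 8 mL/min/kg, also a limit. Compound 2 `CC(C)Oc1cc(Oc2ccc(S(C)(=O)=O)cc2)cc(-c2cncc(=O)[nH]2)c1` gives 11 mL/min/kg.

Compound 4 `COc1cnc(-c2cc(Oc3ccc(S(C)(=O)=O)cc3)cc(OC(C)C)c2)[nH]c1=O` carries one change: methoxy in place of methyl on an aromatic carbon. The nearest measured evidence is an at least 1.3-fold lower number from compound 2 to compound 3 (0.13 log units; that floor lies within the scatter), which concerns the same position. The other readable step is an at least 1.3-fold higher number from compound 1 to compound 2 (0.13 log units; that floor lies within the scatter). Within the data shown here, neither step shows a change beyond the scatter, and no measured compound carries methoxy. In this assay, the expected result is therefore no shift beyond the scatter, with an estimated at least 1.1-fold higher number from compound 3 to compound 4 (0.05 log units; that floor lies within the scatter). The estimate for compound 4 is 9 mL/min/kg, with an expected range from 5 mL/min/kg to 18 mL/min/kg.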

Compound 4, clearance: < 8 mL/min/kg
Compound 4: only a limit was reported; the forecaster's own chance of this, stated with the estimate: 45%; at least 1.1-fold (0.05 log units) between middle value and limit.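

The position on an aromatic carbon takes methoxy as well as methyl without the value in this assay coming off the limit. Among these compounds, the one readable new step is an at least 1.3-fold lower number from compound 2 to compound 4 (0.13 log units; that floor lies within the scatter). The steps from compound 3 and from compound 1 to compound 4 cannot be read, because both ends of each are limits: the limit of < 8 mL/min/kg in this assay, at which 3 of the 4 values shown sit.

Going by these compounds, how far compound 3 and compound 4 each lie beyond that limit stays unknown, so methyl and methoxy cannot be ranked in this assay. On these data alone, whether ethoxy or an amine at this position would bring a readable number also remains open.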